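A larger diamine on the shared core

The compounds below may be only part of what the source reports. "The series", "measured", "known", "first", "only" and "open" are said of these compounds alone.

Three compounds sharing one core differ at a single substituent. In a functional assay on G-361 cells (Homo sapiens) for cytotoxicity, read by fluorescence, with a stated time of 72 h (on this read-out higher numbers stand for weaker inhibition and lower numbers for stronger inhibition), compound 1 `CC(C)c1n[nH]c2c(NCc3ccc(-c4ccccn4)cc3)nc(S(C)(=O)=O)nc12`, bearing methylsulfonyl, gives 793 nM, compound 2 `CC(C)c1n[nH]c2c(NCc3ccc(-c4ccccn4)cc3)nc(N3CCCCC3CCO)nc12` gives 204 nM, and compound 3 `CC(C)c1n[nH]c2c(NCc3ccc(-c4ccccn4)cc3)nc(NCCN)nc12` gives 230 nM. Compound 3 thus lies within the scatter of compound 2 and under compound 1. Compound 4 `CC(C)c1n[nH]c2c(NCc3ccc(-c4ccccn4)cc3)nc(N[C@@H]3CCCC[C@H]3N)nc12` brings (2-aminocyclohexyl in place of 2-aminoethyl on a nitrogen on an aromatic ring), 2-aminocyclohexyl in place of 2-aminoethyl on a nitrogen on an aromatic ring. Two modest steps bear on this, a 3.9-fold lower number from compound 1 to compound 2 (0.59 log units; beyond the scatter) and a 3.4-fold lower number from compound 1 to compound 3 (0.54 log units; beyond the scatter), but the closest comparison, a 1.1-fold higher number from compound 2 to compound 3 (0.05 log units; within the scatter), stays within the scatter. No change beyond the scatter is therefore expected in this assay, and the expected step is a 1.5-fold lower number from compound 3 to compound 4 (0.19 log units; within the scatter). Compound 4 is estimated at 150 nM, within a range of 50 nM to 420 nM.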

Compound 4, half-maximal inhibitory concentration: 477 nM
Compound 4: the middle estimate sits 3.2-fold (0.50 log units) below what was measured, and the stated range ends below it.
By their numbers in this assay, from the lowest: compounds 2 and 3 (each within the scatter of the next); then compounds 4 and 1 (each within the scatter of the next).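

In this assay, this position proves sensitive to what the amine nitrogen carries: 2-aminocyclohexyl in place of 2-aminoethyl gives a 2.1-fold higher number from compound 3 to compound 4 (0.32 log units; beyond the scatter), and the change from 2-(2-hydroxyethyl)piperidin-1-yl gives a 2.3-fold higher number from compound 2 to compound 4 (0.37 log units; beyond the scatter), whereas the two earlier amine-bearing groups stayed within the scatter of each other. The amine no longer separates clearly from methylsulfonyl, with a 1.7-fold lower number from compound 1 to compound 4 (0.22 log units; within the scatter). No evidence at hand explains this shift. The compounds shown leave open whether the mirror-image 2-aminocyclohexyl, a 2-aminocyclopentyl ring or a longer 3-aminopropyl chain on the same nitrogen would track compound 3 or compound 4.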